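A Pyridin-3-yl in Place of the Trifluoromethylphenyl Group

The compounds below may be only part of what the source reports. "The series", "measured", "known", "first", "only" and "open" are said of these compounds alone.

Compound 2 `O=C(O)CC/C=C\CC1COC(c2ccc(C(F)(F)F)cc2)OC1c1cccnc1` gives 44 nM in an assay for inhibition of Thromboxane-A synthase (Homo sapiens), using microsomes; on this read-out higher numbers stand for weaker inhibition and lower numbers for stronger inhibition. Among the measured compounds shown here, of the two numbers measured so far, compound 2 holds the higher one, yet compound 1 `N#Cc1ccc(C2OCC(C/C=C\CCC(=O)O)C(c3cccnc3)O2)cc1`, which gives 24 nM in this assay, sits within the scatter of it, as the step of a 1.8-fold higher number from compound 1 to compound 2 (0.26 log units; within the scatter) shows. Compound 3 `O=C(O)CC/C=C\CC1COC(c2cccnc2)OC1c1cccnc1` differs from compound 2 in one place: pyridin-3-yl in place of 4-(trifluoromethyl)phenyl on a saturated ring carbon. For the measured compounds named here, the only measured step that bears on this change, a 1.8-fold higher number from compound 1 to compound 2 (0.26 log units; within the scatter), concerned a substituent of the ring that now leaves while the ring itself remained, and it stayed within the scatter. No measured step exchanges the whole ring, so the present change has no direct precedent among these compounds. The step from compound 2 to compound 3 is therefore expected to be a 1.1-fold lower number from compound 2 to compound 3 (0.04 log units; within the scatter), not beyond the scatter. The estimate for compound 3 in this assay is 40 nM, with a range from 12 nM to 130 nM.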

Compound 3, half-maximal inhibitory concentration: 220 nM
Compound 3: middle estimate off by 5.5-fold (0.74 log units), on the low side; measured number above the stated range.
By their numbers in this assay, from the lowest: compounds 1 and 2 (each within the scatter of the next); then compound 3.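

In this assay, the step of a 1.8-fold higher number from compound 1 to compound 2 (0.26 log units; within the scatter) stayed within the scatter, but replacing the whole ring on the saturated ring carbon between two ring oxygen atoms does not: a 5.0-fold higher number from compound 2 to compound 3 (0.70 log units; beyond the scatter) and a 9.2-fold higher number from compound 1 to compound 3 (0.96 log units; beyond the scatter) both lie beyond it. This position therefore accepted either 4-cyanophenyl or 4-(trifluoromethyl)phenyl without a change beyond the scatter, yet it is not indifferent to pyridin-3-yl in their place. Nothing available here accounts for this loss.

Still open, going by these compounds, is whether the higher number goes with the ring nitrogen of pyridin-3-yl or with the absence of any substituent on the entering ring. A plain phenyl group here would separate these two readings, while an amine or a carboxylic acid on the phenyl ring would test how widely the substituent can vary.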